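The source may hold more compounds than are shown below. What is called first, only, known or untested is meant among the compounds shown, and "the series" means these compounds.

The series shares one core, seen in compound 1 `Cc1cc(C)c(NC(=O)N(Cc2ccc(-c3cn[nH]c3)cc2)C2CCCCCC2)c(C)c1`, compound 2 `Cc1cc(C)c(NC(=O)N(Cc2ccc(-c3ccn(C)n3)cc2)C2CCCCCC2)c(C)c1` and compound 3 `Cc1cc(C)c(NC(=O)N(Cc2ccc(-c3ccnn3C)cc2)C2CCCCCC2)c(C)c1`, and differs only in the five-membered ring carried on the benzyl group. In an assay on microsomes from intestine for inhibition of acyl-CoA:cholesterol acyltransferase (Oryctolagus cuniculus) (a lower number here means a stronger inhibitor, a higher number a weaker inhibitor), compound 1 gives 270 nM, compound 2 gives 44 nM and compound 3 gives 24 nM. Compound 3 thus has the lowest of the three numbers; its gap to compound 2 is within the scatter, while the step of an 11-fold lower number from compound 1 to compound 3 (1.05 log units; beyond the scatter) is beyond it, as is a 6.1-fold lower number from compound 1 to compound 2 (0.79 log units; beyond the scatter).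

Compound 4 `Cc1cc(C)c(NC(=O)N(Cc2ccc(-n3ccnc3)cc2)C2CCCCCC2)c(C)c1` is the next step from compound 3: 1H-imidazol-1-yl in place of 1-methyl-1H-pyrazol-5-yl on an aromatic carbon. Among the compounds with values here, no measured step covers a nitrogen-linked ring, so none bears on it directly. The measured steps only show that replacing the ring bearing a hydrogen-bond donor by a methylated one lowered the number, as in an 11-fold lower number from compound 1 to compound 3 (1.05 log units; beyond the scatter) and a 1.8-fold lower number from compound 2 to compound 3 (0.26 log units; within the scatter), the latter within the scatter. Compound 4 keeps no donor but also loses the methyl, so the outlook is uncertain. Compound 4 is therefore expected to give a number in this assay somewhat higher than compound 3, with a step of a 2.7-fold higher number from compound 3 to compound 4 (0.43 log units; beyond the scatter), and its estimate is 65 nM, within a range from 20 nM to 220 nM.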

Compound 4, half-maximal inhibitory concentration: 47 nM
For compound 4 the middle estimate is 1.4-fold (0.14 log units) above the measured one; measured number inside the range.
By their numbers in this assay, from the lowest: compounds 3, 2 and 4 (each within the scatter of the next); then compound 1.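

Compound 4 shows that this position, on an aromatic carbon para to a large group, accepts a ring joined through nitrogen and without a methyl group. In this assay, the change to 1H-imidazol-1-yl stays within the scatter of both methylated rings, as a 2.0-fold higher number from compound 3 to compound 4 (0.29 log units; within the scatter) and a 1.1-fold higher number from compound 2 to compound 4 (0.03 log units; within the scatter) show, so a methyl group on the five-membered ring is not required for a number in this range. The new ring also keeps the clear separation from the 1H-pyrazol-4-yl ring, with a 5.7-fold lower number from compound 1 to compound 4 (0.76 log units; beyond the scatter), leaving that ring as the only one of the four set apart, although nothing measured alongside these numbers explains the difference.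

The change to compound 4 alters the ring's point of attachment and removes the methyl group together, so the compounds shown do not separate the contribution of either change. They also leave open how a 1H-imidazol-1-yl ring carrying a methyl group, a 1,2,4-triazol-1-yl ring or a simple phenyl ring would behave at this position, and whether any of these would stay within the scatter of the rings already seen.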